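Swapping the pyridine group on compound 2

The source may hold more compounds than are shown below. What is called first, only, known or untested is meant among the compounds shown, and "the series" means these compounds.

In a physicochemical assay for solubility, in phosphate buffer, at pH 6.5 (a higher number here means a more soluble compound, a lower number a less soluble compound), compound 2 `CCOc1cc(CN2CCC(NC(=O)c3cncc(C)c3)CC2)ccc1C` gives > 433 ug/mL, which is a limit and not a number.

Compound 4 `CCOc1cc(CN2CCC(NC(=O)c3ccc(N)nc3)CC2)ccc1C` differs from it in one place, 6-aminopyridin-3-yl in place of 5-methylpyridin-3-yl on a carbonyl carbon. Compound 3 `CCOc1cc(CN2CCC(NC(=O)c3cncc(C)c3)CC2)ccc1-c1ccc(F)cc1` gives 101 ug/mL, and compound 1 `CCOc1cc(CN2CCC(NC(=O)c3ccc(Cl)nc3)CC2)cc(OCC)c1-c1ccc(F)cc1` gives 76 ug/mL.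

Among the measured compounds shown here, the only measured step, an at least 4.2-fold lower number from compound 2 to compound 3 (0.63 log units; beyond the scatter), puts 4-fluorophenyl in place of methyl on an aromatic carbon, not at the carbonyl, so it offers only a loose guide. A modest drop in this assay is therefore expected, with an estimated at least 1.4-fold lower number from compound 2 to compound 4 (0.15 log units; that floor lies within the scatter). Compound 4 is expected at about 300 ug/mL, with an estimated range of 120 ug/mL to 500 ug/mL.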

Compound 4, solubility: 375 ug/mL
Estimate against measurement, compound 4: 1.3-fold (0.10 log units) below; the measured number falls inside the stated range.
By their numbers in this assay, from the lowest: compounds 1 and 3 (each within the scatter of the next); then compound 4. At a limit, above all of these: compound 2.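

Placed on the carbonyl carbon, 6-aminopyridin-3-yl in place of 5-methylpyridin-3-yl gives, in this assay, an at least 1.1-fold lower number from compound 2 to compound 4 (0.06 log units; that floor lies within the scatter), so this swap shows no clear loss, unlike the change on the aromatic carbon, an at least 4.2-fold lower number from compound 2 to compound 3 (0.63 log units; beyond the scatter). Compound 4 gives a true number, 375 ug/mL, and so sets a measured reference for this position. Compound 2 stands at a limit, which is not a number, so the true size of the step stays unknown: the limit of > 433 ug/mL in this assay, at which 1 of the 4 values shown sits.

Going by these compounds, how a plain phenyl or a carboxylic acid-bearing pyridine on the carbonyl carbon would read in this assay remains open.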